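Boc-anilino for methyl ester on the arylalkyne

This account rests on a few compounds, and the source may have more. Where it says the series, first, only, none or still open, it means among the compounds named here.

Compound 1 `COC(=O)c1ccc(C#CCCCCC(=O)c2ncc(-c3ccccn3)o2)cc1`: 25 nM; compound 2 `O=C(CCCCC#Cc1cccnc1)c1ncc(-c2ccccn2)o1`: 300 nM; compound 3 `O=C(CCCCC#Cc1cccc(Cl)c1Cl)c1ncc(-c2ccccn2)o1`: 5 nM.

In an assay for inhibition of Fatty-acid amide hydrolase 1 (Rattus norvegicus) (a higher number here means a weaker inhibitor, a lower number a stronger inhibitor), compound 1 stands second highest of the three numbers, between compound 3 below it and compound 2 above it. Within the data shown here, the only step available, a 60-fold lower number from compound 2 to compound 3 (1.78 log units; beyond the scatter), swaps the whole ring on the triple-bonded carbon and does not address a substituent exchange on a retained phenyl ring. Compound 4 `CC(C)(C)OC(=O)Nc1ccc(C#CCCCCC(=O)c2ncc(-c3ccccn3)o2)cc1` differs from compound 1 by (tert-butoxycarbonyl)amino in place of methoxycarbonyl on an aromatic carbon. Among the measured compounds shown here, no measured pair shows this change, so compound 4 is expected to give a number near that of compound 1, with the step of a 1.2-fold higher number from compound 1 to compound 4 (0.08 log units; within the scatter) estimated to lie within the scatter. For compound 4 the estimate in this assay is 30 nM, with a range from 8 nM to 120 nM.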

Compound 4, inhibition constant: 23 nM
The estimate for compound 4 lay 1.3-fold (0.12 log units) above the measured number, within the range that was stated.
By their numbers in this assay, from the lowest: compound 3; then compounds 4 and 1 (each within the scatter of the next); then compound 2.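

In this assay, the exchange of methoxycarbonyl for (tert-butoxycarbonyl)amino gives a 1.1-fold lower number from compound 1 to compound 4 (0.04 log units; within the scatter), so the two compounds cannot be told apart. This aromatic carbon, para to a large group, thus carries either group with no separation in the read-out, although the entering group has more heavy atoms and a hydrogen-bond donor, something the earlier whole-ring step could not show. Nothing available explains this result. On these data alone, whether a free amine or a carboxylic acid on this carbon would also stay within the scatter of compound 1 remains open.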